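Compound 3 to compound 4: piperazin-1-yl replaced by hydrogen

The source may hold more compounds than are shown below. What is called first, only, known or untested is meant among the compounds shown, and "the series" means these compounds.

In a functional assay on HT cells (Homo sapiens) for antiproliferative activity, read by fluorescence, with a stated time of 72 h (a lower number here means a stronger inhibitor of growth, a higher number a weaker inhibitor of growth), compound 3 `CC(C)c1n[nH]c2c(NCc3ccc(-c4ccccn4)cc3)nc(SCC(O)CN3CCNCC3)nc12` gives 332 nM, the middle of the three numbers in hand. Compound 1 `CC(C)c1n[nH]c2c(NCc3ccc(-c4ccccn4)cc3)nc(SCC3CNC(=O)O3)nc12` lies lower at 80 nM, and compound 2 `CC(C)c1n[nH]c2c(NCc3ccc(-c4ccccn4)cc3)nc(SCC(O)C(F)(F)F)nc12` lies higher at 690 nM.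

Compound 4 `CC(O)CSc1nc(NCc2ccc(-c3ccccn3)cc2)c2[nH]nc(C(C)C)c2n1` has not yet been measured. Its difference from compound 3 is hydrogen in place of piperazin-1-yl on a saturated chain carbon, two bonds along the chain from an oxygen on a saturated carbon. Cut one bond further out, the same difference reads (piperazin-1-yl)methyl to methyl.

The closest evidence is the change at that same carbon, where (piperazin-1-yl)methyl stands in place of trifluoromethyl: a 2.1-fold lower number from compound 2 to compound 3 (0.32 log units; beyond the scatter). This step is modest. The steps of an 8.6-fold higher number from compound 1 to compound 2 (0.94 log units; beyond the scatter) and a 4.2-fold higher number from compound 1 to compound 3 (0.62 log units; beyond the scatter) are somewhat larger, but both remove the 2-oxo-1,3-oxazolidin-5-yl group, so they bear on the change less directly. Compound 2 and compound 3 both keep the open hydroxy chain that compound 4 carries, and both stand above compound 1. Within the data shown here, no measured compound has methyl at this carbon, so the data set no firm direction for the change.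

The expected result is a 1.2-fold higher number from compound 3 to compound 4 (0.08 log units; within the scatter), a step not expected to exceed the scatter. For compound 4 the estimated value is 400 nM, with an expected range of 130 nM to 1000 nM.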

Compound 4, concentration for 50% growth inhibition: 62 nM
Compound 4: the middle estimate sits 6.5-fold (0.81 log units) above what was measured; the whole stated range lies above it.
By their numbers in this assay, from the lowest: compounds 4 and 1 (each within the scatter of the next); then compound 3; then compound 2.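

In this assay the group at the end of this chain turns out to matter: hydrogen in place of piperazin-1-yl gives a 5.4-fold lower number from compound 3 to compound 4 (0.73 log units; beyond the scatter) and shows that the (piperazin-1-yl)methyl group of compound 3 costs activity relative to plain methyl. Methyl in place of trifluoromethyl at the same carbon gives an 11-fold lower number from compound 2 to compound 4 (1.05 log units; beyond the scatter) and is the only large step in the set, so an open hydroxy chain is no longer tied to the higher numbers that compound 2 and compound 3 suggested. The 2-oxo-1,3-oxazolidin-5-yl ring of compound 1 is also not needed for a number in this range, as 1-hydroxyethyl in its place gives a 1.3-fold lower number from compound 1 to compound 4 (0.11 log units; within the scatter) and stays within the scatter.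

No measurement in hand accounts for any of these steps.

Still open is whether an ethyl or a longer alkyl chain at this carbon, or a dimethylamino group in place of piperazin-1-yl, stays level with compound 4 or moves towards compound 3, and whether the oxygen on the saturated carbon is needed at all, given that every compound shown keeps it.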